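This account rests on a few compounds, and the source may have more. Where it says the series, first, only, none or still open, it means among the compounds named here.

Working notes on the series. Three compounds have been run in a functional assay on HBL-100 cells (Homo sapiens) for inhibition, read by sulforhodamine B assay, with a stated time of 48 h; a higher number here means a weaker inhibitor of growth, a lower number a stronger inhibitor of growth. Compound 1 `COC(=O)[C@@]1(C)CCC=C2[C@@H]1CC[C@@H](C)[C@]2(C)Cc1c[nH]c2ccc(Cl)cc12` gives 17000 nM. Compound 2 `COC(=O)[C@@]1(C)CCC=C2[C@@H]1CC[C@@H](C)[C@]2(C)Cc1c[nH]c2c(C)cccc12` gives 8000 nM. Compound 3 `COC(=O)[C@@]1(C)CC[C@@H]2C3=C1CC[C@@H](C)[C@]3(C)C[C@@H]1c3cccc(C)c3N[C@H]21` gives 32000 nM, the highest number of the three; its gap to compound 1 lies within the scatter, while its gap to compound 2 lies beyond it. Compounds 1 and 2 differ from each other in more than one place, so their two values stand side by side and are not read as a step.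

Compound 4 `COC(=O)[C@@]1(C)CC[C@@H]2C3=C1CC[C@@H](C)[C@]3(C)C[C@@H]1c3cccc(Cl)c3N[C@H]21` is not yet measured. It differs from compound 3 by chloro in place of methyl on an aromatic carbon. For the measured compounds named here, no measured pair in the set carries this single change, so there is no step to lean on; the only available comparison, compound 1 against compound 2, mixes a change of substituent with a change of position and gives no clean reading. The expectation is a step from compound 3 to compound 4 of no size beyond the scatter, at most a slight rise, a 1.3-fold higher number from compound 3 to compound 4 (0.10 log units; within the scatter). For compound 4 the estimate in this assay is 40000 nM, with a range from 15000 nM to 100000 nM.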

Compound 4, concentration for 50% growth inhibition: 52000 nM
The estimate for compound 4 lay 1.3-fold (0.11 log units) below the measured number; measured number inside the range.
By their numbers in this assay, from the lowest: compound 2; then compounds 1, 3 and 4 (each within the scatter of the next, the first and the last beyond it).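

In this assay, for the compounds shown here, chloro in place of methyl on this aromatic carbon, ortho to a fused ring and meta to a fused ring, gives a 1.6-fold higher number from compound 3 to compound 4 (0.21 log units; within the scatter) as the first single-change step. At this place, the methyl and chloro groups are not told apart by this read-out, so the swap shows no effect on growth inhibition that stands clear of the scatter. No measured property of either group bears on this result.

From the compounds shown here alone, it remains open whether another group at this place, such as an amine, a carboxylic acid or a longer chain, would give a step beyond the scatter. Going by these compounds, it is also open whether the same swap at the same place would read alike on the core of compound 2.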